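The compounds below may be only part of what the source reports. "The series", "measured", "known", "first", "only" and "open" are said of these compounds alone.

In an assay on nucleic acid for binding affinity to Calf thymus DNA (Bos taurus) (on this read-out lower numbers stand for stronger inhibition and higher numbers for weaker inhibition), compound 1 `CCCN(CCC)CCn1c2ccc3ccccc3c2c2nc3ccccc3nc21` gives 15800 nM. Compound 2 `CC1CCCCN1CCn1c2ccc3ccccc3c2c2nc3ccccc3nc21` gives 18600 nM in this assay, so compound 1 sits alongside compound 2 within the scatter rather than apart from it. Among the compounds with values here, the only known step, a 1.2-fold higher number from compound 1 to compound 2 (0.07 log units; within the scatter), is a ring closure of the same kind at the same place and did not move the number beyond the scatter. Compound 3 `CC1CCN(CCn2c3ccc4ccccc4c3c3nc4ccccc4nc32)CC1` differs from compound 1 by 4-methylpiperidin-1-yl in place of dipropylamino on a saturated chain carbon, two bonds along the chain from an aromatic nitrogen. On that single comparison, no step beyond the scatter is expected in this assay. For compound 3 the expected value is 17000 nM, with a range from 8000 nM to 36000 nM. That estimate for compound 3 means an expected step of a 1.1-fold higher number from compound 1 to compound 3 (0.03 log units; within the scatter).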

Compound 3, half-maximal inhibitory concentration: 33100 nM
The estimate for compound 3 lay 1.9-fold (0.29 log units) below the measured number; measured number inside the range.
By their numbers in this assay, from the lowest: compounds 1, 2 and 3 (each within the scatter of the next, the first and the last beyond it).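

In this assay, within the data shown here, 4-methylpiperidin-1-yl in place of dipropylamino gives a 2.1-fold higher number from compound 1 to compound 3 (0.32 log units; beyond the scatter), the first step at this place on the chain to pass beyond the scatter, though only modestly. Moving the methyl group on the piperidine ring gives a 1.8-fold higher number from compound 2 to compound 3 (0.25 log units; within the scatter), so the two methylpiperidin-1-yl compounds stay within the scatter of each other. Nothing measured here accounts for the step. Open, on these data alone, is how piperidin-1-yl without a methyl group, or morpholin-4-yl, would read at this place, and whether a longer chain to the amine would change these numbers.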